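Urea series: trifluoromethyl on the benzyl ether of compound 3

The source may hold more compounds than are shown below. What is called first, only, known or untested is meant among the compounds shown, and "the series" means these compounds.

Compound 3 `Cc1ccc(NC(=O)NC(=O)c2ccc(OCc3ccccc3)cc2)cc1-c1nc2ccccc2[nH]1` is the urea member of the set, carrying an unsubstituted benzyl on the ether oxygen. In a functional assay on MNK45 cells (Homo sapiens) for inhibition, read by MTT assay, with a stated time of 48 h (a lower number here means a stronger inhibitor, a higher number a weaker inhibitor), compound 3 gives 35100 nM, the highest number of the three measured compounds; the thiourea compound 1 `Cc1ccc(NC(=S)NC(=O)c2ccc(OCc3ccc(C(F)(F)F)cc3)cc2)cc1-c1nc2ccccc2[nH]1` gives 10200 nM and the thiourea compound 2 `Cc1ccc(NC(=S)NC(=O)c2ccc(OCc3ccccc3F)cc2)cc1-c1nc2ccccc2[nH]1` gives 2420 nM, both lower, with compound 2 furthest away. Compound 4 `Cc1ccc(NC(=O)NC(=O)c2ccc(OCc3cccc(C(F)(F)F)c3)cc2)cc1-c1nc2ccccc2[nH]1` keeps the urea of compound 3 and differs by one change: trifluoromethyl in place of hydrogen on an aromatic carbon.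

Among the measured compounds shown here, the only measured step, a 4.2-fold lower number from compound 1 to compound 2 (0.62 log units; beyond the scatter), touches the same benzyl position but exchanges 4-(trifluoromethyl)phenyl for 2-fluorophenyl within the thiourea pair, so it does not isolate the trifluoromethyl itself, and it does not place the group meta to a large group as in compound 4. It does show that the trifluoromethyl-bearing member of that pair was the weaker one by a modest margin. For the measured compounds named here, no step on the urea scaffold exists. The expectation for compound 4 is therefore a small move toward a higher number, or none beyond the scatter, a 1.3-fold higher number from compound 3 to compound 4 (0.11 log units; within the scatter). Compound 4 is estimated at 45000 nM in this assay, within a range of 15000 nM to 130000 nM.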

Compound 4, half-maximal inhibitory concentration: 9600 nM
The estimate for compound 4 lay 4.7-fold (0.67 log units) above the measured number; measured number outside the range, below it.
By their numbers in this assay, from the lowest: compound 2; then compounds 4 and 1 (each within the scatter of the next); then compound 3.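

In this assay, trifluoromethyl in place of hydrogen on an aromatic carbon, meta to a large group, gives a 3.7-fold lower number from compound 3 to compound 4 (0.56 log units; beyond the scatter), the first step read on the urea scaffold, and it shows that this substitution on the benzyl ring can go with a lower number. The earlier step, a 4.2-fold lower number from compound 1 to compound 2 (0.62 log units; beyond the scatter), left the trifluoromethyl-bearing member as the higher of the thiourea pair, but it exchanged 4-(trifluoromethyl)phenyl for 2-fluorophenyl, so it never measured the group against hydrogen; the new step does so directly, though on one scaffold and in one place only. Nothing available accounts for the lower number.

From the compounds shown here alone, it remains open whether the step belongs to trifluoromethyl as such or would also follow a chlorine, a methoxy or a nitrile in the same place, and whether the same change would hold with the group as 4-(trifluoromethyl)phenyl or on the thiourea. The urea and thiourea also remain unseparated, since the compounds shown offer no pair that differs in that place alone.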